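Anilide variation on a shared piperazine core: compound 3

A few compounds are considered here, and "the series" means these few. Any claim that something is new, unique, unknown or untested is made for them only; others in the source may bear on it.

Measured compounds in a functional assay on A549 cells (Homo sapiens) for cytotoxicity, read by MTT assay, with a stated time of 72 h; a higher number here means a weaker inhibitor, a lower number a stronger inhibitor:
- compound 1 `O=C(CN1CCN(c2nnc(Cc3ccccc3)c3ccccc23)CC1)Nc1ccc(F)c(C(F)(F)F)c1`: 2480 nM
- compound 2 `Cc1ccccc1NC(=O)CN1CCN(c2nnc(Cc3ccccc3)c3ccccc23)CC1`: "not active" (no number reported)

Within the data shown here, compound 1 is the only member of the set with a number in this assay, where compound 1 gives 2480 nM. Compound 2 stands without a single number in this assay: for compound 2 the result is recorded as "not active" (no number reported), so its position relative to compound 1 can only be described as weaker, not by a size.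

Compound 3 `O=C(CN1CCN(c2nnc(Cc3ccccc3)c3ccccc23)CC1)Nc1cccc(Br)c1` is not yet measured. It differs from compound 2 in one place: 3-bromophenyl in place of 2-methylphenyl on an amide-type nitrogen. Among the measured compounds shown here, no step between measured compounds is available, so the size of this change cannot be read from the data. Given that compound 2 reports "not active" (no number reported) and that compound 1, with a different substituted phenyl on the same amide-type nitrogen, gives 2480 nM, a weak result is expected for compound 3, with a real chance that this assay again reports no number at all. For compound 3 the estimated value in this assay is 6000 nM, within a range of 1500 nM to 30000 nM.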

Compound 3, half-maximal inhibitory concentration: "not active" (no number reported)
Compound 3 has no reported number here, and the estimate cannot be compared.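

In this assay compound 2 and compound 3 both stand without a number, so no step can be read between them and the change from 2-methylphenyl to 3-bromophenyl has no size. No measured property bears on this result. The compounds shown leave open how far compound 1 at 2480 nM stands from compound 2 and compound 3.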